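Moving the Ring Nitrogen on a Piperidine Amide

A few compounds are considered here, and "the series" means these few. Any claim that something is new, unique, unknown or untested is made for them only; others in the source may bear on it.

Compound 2 `CCN(C(=O)c1ccccc1OCc1ccccc1)C1CCCNC1` carries a piperidin-3-yl group on its amide nitrogen. In an assay on HEK293 cells for inhibition of transient receptor potential cation channel subfamily M member 8 (Homo sapiens), read by FLIPR and calcium flux (a lower number here means a stronger inhibitor, a higher number a weaker inhibitor), compound 2 gives 4860 nM. Compound 1 `CCN(C(=O)c1ccccc1OCc1ccccc1)[C@@H]1CC[C@@H](N)C1` gives 2600 nM, and the step of a 1.9-fold higher number from compound 1 to compound 2 (0.27 log units; within the scatter) lies within the scatter, so the two stand level. Compound 3 `CCN(C(=O)c1ccccc1OCc1ccccc1)C1CCNCC1` differs from compound 2 only by piperidin-4-yl in place of piperidin-3-yl on an amide-type nitrogen. Among the compounds with values here, the one measured step, which exchanged one saturated ring for another, barely moved this assay, so shifting the ring nitrogen is expected to give no step beyond the scatter, a 1.2-fold lower number from compound 2 to compound 3 (0.08 log units; within the scatter). Compound 3 is therefore estimated at 4000 nM, within a range from 1500 nM to 11000 nM.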

Compound 3, antagonist equilibrium constant: > 5000 nM
Compound 3: no number, only a limit; the forecaster's own chance of this, stated with the estimate: 10%; at least 1.2-fold (0.09 log units) between middle value and limit.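

Compound 3 gives no number in this assay, only a limit: the limit of > 5000 nM in this assay, at which 1 of the 3 values shown sits.

Piperidin-4-yl in place of piperidin-3-yl can therefore be read only as a floor, an at least 1.0-fold higher number from compound 2 to compound 3 (0.01 log units; that floor lies within the scatter), and the comparison with the five-membered ring gives another floor, an at least 1.9-fold higher number from compound 1 to compound 3 (0.28 log units; that floor lies within the scatter). Neither floor shows a step beyond the scatter, yet the true size of either step could be larger, so this position may or may not respond to where the ring nitrogen sits.

On these data alone, how a methyl group on the ring nitrogen would read in this assay remains open.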